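Branching the amine on a longer amide chain

The compounds below may be only part of what the source reports. "The series", "measured", "known", "first", "only" and "open" are said of these compounds alone.

Three measured compounds share one core and differ only in the side chain that ends in the amide. Compound 1 `CCNCC(=O)Nc1cccc2c1CN(C)CC2c1ccccc1` carries an ethylamino group on a saturated chain carbon bound to a carbonyl carbon. In a functional assay on the whole organism for inhibition of sodium-dependent dopamine transporter (Mus musculus) (on this read-out higher numbers stand for an effect only at larger amounts of compound and lower numbers for an effect already at smaller amounts), compound 1 gives about 60 mg/kg. Compound 2 `CC(C)NCC(=O)Nc1cccc2c1CN(C)CC2c1ccccc1` differs from compound 1 by methyl in place of hydrogen on a saturated chain carbon bound to an amine nitrogen and a saturated chain carbon, and in this assay compound 2 gives about 30 mg/kg; this change made a 2.0-fold lower number from compound 1 to compound 2 (0.30 log units; within the scatter). Compound 3 `CCNCCC(=O)Nc1cccc2c1CN(C)CC2c1ccccc1` differs from compound 1 in the length of the chain, by (ethylamino)methyl in place of ethylamino on a saturated chain carbon bound to a carbonyl carbon, and in this assay compound 3 gives 190 mg/kg. That lengthening made a 3.2-fold higher number from compound 1 to compound 3 (0.50 log units; beyond the scatter), and measured against the branched analogue it made a 6.3-fold higher number from compound 2 to compound 3 (0.80 log units; beyond the scatter). Compound 3 thus stands at the highest number of the three.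

Compound 4 `CC(C)NCCC(=O)Nc1cccc2c1CN(C)CC2c1ccccc1` has not yet been measured. It differs from compound 3 by methyl in place of hydrogen on a saturated chain carbon bound to an amine nitrogen and a saturated chain carbon, the same change that separates compound 1 from compound 2, at a place described in identical words. For the measured compounds named here, the first instance of this change left the number within the scatter, and with only one such example there is little reason to expect anything different on the longer chain. For compound 4 the expected step from compound 3 is a 2.0-fold lower number from compound 3 to compound 4 (0.30 log units; within the scatter), because a 2.0-fold lower number from compound 1 to compound 2 (0.30 log units; within the scatter) was the outcome of the same change. Compound 4 is accordingly estimated at 95 mg/kg in this assay, with a likely range from 45 mg/kg to 200 mg/kg.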

Compound 4, dose for half-maximal effect: about 200 mg/kg
The estimate for compound 4 lay 2.1-fold (0.32 log units) below the measured number; the measured number falls inside the stated range.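

In this assay, adding the methyl to the longer chain gave a 1.1-fold higher number from compound 3 to compound 4 (0.02 log units; within the scatter), so the change that turns ethylamino into isopropylamino made no clear difference on either chain, and the two cases agree:  the same change on two cores in this assay, a 2.0-fold lower number (0.30 log units; within the scatter) from compound 1 to compound 2 and a 1.1-fold higher number (0.02 log units; within the scatter) from compound 3 to compound 4, 2.1-fold (0.32 log units) apart, within the scatter of two such steps

For the compounds shown here, this agreement shows only that the change carried over between these two closely related compounds pairs, with a small step each time, and two pairs are too few to make a rule for the series. Since both steps lie within the scatter, they also cannot show whether the methyl has a small real effect or none at all. The longer chain stands out more clearly, with a 6.7-fold higher number from compound 2 to compound 4 (0.82 log units; beyond the scatter) and a 3.3-fold higher number from compound 1 to compound 4 (0.52 log units; beyond the scatter), although each of these two steps changes the amine group as well as the chain length.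

The compounds shown leave open whether a bulkier group on the amine, such as tert-butyl, or a ring amine such as piperidine would also leave the number unchanged. They also leave open whether a still longer chain would push the number higher again.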